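This account rests on a few compounds, and the source may have more. Where it says the series, first, only, none or still open, it means among the compounds named here.

Measured in a functional assay on MDA-MB-231 cells (Homo sapiens) for inhibition, read by MTT assay, with a stated time of 72 h; on this read-out lower numbers stand for stronger inhibition and higher numbers for weaker inhibition:
- compound 1 `CC1=NN(c2ccccc2)C(=O)[C@]12C(=O)C=CC[C@H]2c1ccccc1[N+](=O)[O-]`: 32400 nM
- compound 2 `CC1=NN(c2ccccc2)C(=O)[C@@]12C(=O)C=CC[C@@H]2c1ccccc1[N+](=O)[O-]`: 68300 nM

Of these two, compound 2 stands highest at 68300 nM, making it the weaker inhibitor of the pair in this assay. The next structure, compound 3 `COc1ccccc1[C@H]1CC=CC(=O)[C@@]12C(=O)N(c1ccccc1)N=C2C`, keeps the shared core and differs from compound 2 at one place, on an aromatic carbon ortho to a large group: methoxy in place of nitro on an aromatic carbon. In words, methoxy stands in place of nitro.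

Going by the values given here, only one measured step is available, a 2.1-fold higher number from compound 1 to compound 2 (0.32 log units; beyond the scatter), and it is a modest one. It rests on (the fact that compounds 1 and 2 differ only in the configuration as drawn), so it bears on the aromatic substituent only indirectly. Among the compounds with values here, both measured compounds carry nitro, and no measured step tests a replacement at this place. Within the data shown here, the size of the mirror-image step from compound 1 to compound 2 is therefore the only guide to how far numbers move in this small set. It gives no direction for the new change. A shift of no more than that modest size is expected, with little or no movement beyond the scatter. The expected change is a 1.1-fold lower number from compound 2 to compound 3 (0.06 log units; within the scatter). For compound 3 the estimated value is 60000 nM, with an expected range of 22000 nM to 130000 nM.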

Compound 3, half-maximal inhibitory concentration: 15700 nM
Compound 3: middle estimate off by 3.8-fold (0.58 log units), on the high side, outside the stated range (below it).
By their numbers in this assay, from the lowest: compound 3; then compound 1; then compound 2.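

In this assay, going by these compounds alone, the replacement of nitro by methoxy on the aromatic carbon gives a 4.4-fold lower number from compound 2 to compound 3 (0.64 log units; beyond the scatter), the first step that reads this place directly. With the configuration as drawn kept the same, the place ortho to a large group responds to substitution, and nitro is not required for inhibition in this small set, since the 2-methoxyphenyl compound gives the lower number of the pair. The step is modest and rests on a single pair, and nothing available accounts for its direction or size.

From the compounds shown here alone, it remains open whether methoxy in place of nitro gives a step of the same direction and size in the mirror-image configuration, which would show whether the substituent and configuration steps act independently of each other. Going by these compounds, it is also open how far the number moves with other groups at this aromatic carbon, such as an amine, a carboxylic acid or a longer chain like ethoxy, and whether any of them goes further than methoxy in the same direction.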